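Notes on the sulfonyl substituent change from compound 2

This account rests on a few compounds, and the source may have more. Where it says the series, first, only, none or still open, it means among the compounds named here.

Measured so far:
compound 1 `COc1ccc(NS(=O)(=O)c2ccc3c(c2)C(n2ccccc2=O)=CC(C)(C)O3)cc1` gives 117 nM
compound 2 `CC1(C)C=C(n2ccccc2=O)c2cc(S(=O)(=O)Nc3ccc(C#N)cc3)ccc2O1` gives 263 nM

Both numbers come from a functional assay with Rattus norvegicus as the target; on this read-out lower numbers stand for an effect already at smaller amounts and higher numbers for an effect only at larger amounts of compound. For the measured compounds named here, compound 2 stands at the higher of the two measured values; the only neighbour is compound 1, and the step of a 2.2-fold higher number from compound 1 to compound 2 (0.35 log units; beyond the scatter) is a modest one, beyond the scatter, for a cyano in place of a methoxy on the aromatic ring of the sulfonamide.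

Compound 3 `CC1(C)C=C(n2ccccc2=O)c2cc(S(=O)(=O)Oc3ccccc3)ccc2O1` is not yet measured. Relative to compound 2 it carries phenoxy in place of (4-cyanophenyl)amino on a sulfonyl sulfur. Going by the values given here, no measured step bears directly on this change: the one step seen so far, a 2.2-fold higher number from compound 1 to compound 2 (0.35 log units; beyond the scatter), only varies a substituent on that ring and leaves the sulfonamide itself untouched, so it sets a floor for how much a change at this position can move the number but says nothing about a swap of the whole group. The expectation for compound 3 in this assay is therefore a step of a 2.3-fold higher number from compound 2 to compound 3 (0.36 log units; beyond the scatter), most likely towards a higher number, with wide uncertainty in both directions. Compound 3 is estimated at 600 nM, within a range of 150 nM to 2500 nM.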

Compound 3, half-maximal effective concentration: 2.51 nM
Beside the measured number, compound 3's estimate is 240-fold (2.38 log units) above it; the measured number lies below the stated range.
By their numbers in this assay, from the lowest: compound 3; then compound 1; then compound 2.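

In this assay, the sulfonyl sulfur position proves far more sensitive to exchanging the whole group than to changing a substituent on its ring: a 2.2-fold higher number from compound 1 to compound 2 (0.35 log units; beyond the scatter) is a modest step, whereas phenoxy in place of (4-cyanophenyl)amino gives a 100-fold lower number from compound 2 to compound 3 (2.02 log units; beyond the scatter) and phenoxy in place of (4-methoxyphenyl)amino gives a 47-fold lower number from compound 1 to compound 3 (1.67 log units; beyond the scatter) in the same direction. Compound 3 therefore holds the lowest number of the three, and the large drop appears from both substituted sulfonamides, not from just one of them. No measured data on any property of these compounds accompany the result, so the size of the drop remains unexplained.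

Each step to compound 3 exchanges the amino link for an oxygen and removes the ring substituent at once, so the compounds shown leave open which of the two carries the change; phenylamino or 4-cyanophenoxy on the sulfonyl sulfur would separate them. Also open, going by these compounds, is how far the low number extends to other groups at this place, such as methoxy, benzyloxy or a cyclic amine like piperidine.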